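Swapping the ester acid: pyrrolidine ring out, open chain in

The source may hold more compounds than are shown below. What is called first, only, known or untested is meant among the compounds shown, and "the series" means these compounds.

Compound 2 `C#CCn1cc(C(=O)N[C@@H](C)CCOC(=O)[C@H]2CCCN2C(=O)OC(C)(C)C)c(=O)c2ccc(Cl)nc21`: 6600 nM
Compound 1 `C#CCn1cc(C(=O)NCCCOC(=O)[C@H](C)NC(=O)OC(C)(C)C)c(=O)c2ccc(Cl)nc21`: > 10000 nM

Among the compounds with values here, in a functional assay on KB cells (Homo sapiens) for cytotoxicity, read by MTT assay, with a stated time of 72 h (a higher number here means a weaker inhibitor, a lower number a stronger inhibitor), compound 2 gives 6600 nM, and this is the only number among the values shown. Compound 1 reaches only a limit there: in this assay compound 1 gives > 10000 nM, which is a limit of the assay and not a number.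

Compound 3 `C#CCn1cc(C(=O)N[C@@H](C)CCOC(=O)[C@H](C)NC(=O)OC(C)(C)C)c(=O)c2ccc(Cl)nc21` has not been measured. It differs from compound 2 in one place: 1-((tert-butoxycarbonyl)amino)ethyl in place of 1-(tert-butoxycarbonyl)pyrrolidin-2-yl on a carbonyl carbon. Within the data shown here, no measured pair here differs in a single place, so the size of such a step is not known from these compounds. Given that compound 2 is itself weak, the author expects the step in this assay from compound 2 to compound 3 to be small, toward weaker inhibition or none beyond the scatter, with a real chance that compound 3 reaches only the limit.

The estimate for compound 3 in this assay is 9000 nM, in the range 3000 nM to 30000 nM, a step of a 1.4-fold higher number from compound 2 to compound 3 (0.13 log units; within the scatter).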

Compound 3, half-maximal inhibitory concentration: 8300 nM
Compound 3: the middle estimate sits 1.1-fold (0.04 log units) above what was measured; the range from low to high includes it.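

Within the data shown here, with this pair, this assay gives the first comparison at this place, on a carbonyl carbon whose other neighbours are an oxygen next to a carbonyl group: 1-((tert-butoxycarbonyl)amino)ethyl in place of 1-(tert-butoxycarbonyl)pyrrolidin-2-yl, which removes the ring and adds a hydrogen-bond donor, gives a 1.3-fold higher number from compound 2 to compound 3 (0.10 log units; within the scatter), so no real change can be read. Methyl in place of hydrogen on a saturated chain carbon bound to an amide-type nitrogen and a saturated chain carbon gives an at least 1.2-fold lower number from compound 1 to compound 3 (0.08 log units; that floor lies within the scatter), a second single change. That step is only a floor because compound 1 stands at a limit of the assay and not at a number: the limit of > 10000 nM in this assay, at which 1 of the 3 values shown sits.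

From the compounds shown here alone, all three compounds keep the tert-butoxycarbonyl group, so what a free amine would do at this place remains open. Going by these compounds, whether a longer chain on the ester acid would shift the value also remains open.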